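The source may report more compounds than this note shows. Statements on the series, on what has been measured and on what is new or still open speak of the compounds shown alone.

For the measured compounds named here, compound 1, `COc1cc(/C=C/C(=O)c2sc(Nc3ccccc3C)nc2C)cc(OC)c1OC`, gives 10300 nM in a functional assay on Bel-7402 cells (Homo sapiens) for cytotoxicity, read by MTT assay (a higher number here means a weaker inhibitor, a lower number a stronger inhibitor), and that is the only number among the values shown. Compound 2, `COc1ccc(/C=C/C(=O)c2sc(Nc3ccc(Cl)c(Cl)c3)nc2C)cc1`, reaches only a limit of the assay, > 25000 nM in this assay. Going by the values given here, compound 1 therefore stands alone as the single measured number, the other value being (the limit of > 25000 nM in this assay, at which 1 of the 2 values shown sits). Compound 3, `COc1cc(/C=C/C(=O)c2sc(Nc3cccc(C)c3)nc2C)cc(OC)c1OC`, carries 3-methylphenyl in place of 2-methylphenyl on a nitrogen on an aromatic ring. Among the compounds with values here, no measured step covers this change, so a shift in this assay no larger than the usual scatter, in either direction, is expected. Compound 3 is estimated at 10000 nM, between 4000 nM and 25000 nM. The step this implies, a 1.0-fold lower number from compound 1 to compound 3 (0.01 log units; within the scatter), is expected to stay within the scatter.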

Compound 3, half-maximal inhibitory concentration: > 25000 nM
Compound 3: no number, only a limit; the forecaster's own chance of this, stated with the estimate: 25%; middle value at least 2.5-fold (0.39 log units) from the limit.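

Moving the methyl group, from 2-methylphenyl to 3-methylphenyl on the nitrogen, is not a neutral change in this assay: it gives an at least 2.4-fold higher number from compound 1 to compound 3 (0.38 log units; beyond the scatter). From the compounds shown here alone, compound 3 gives > 25000 nM, which is a limit of the assay and not a number, so the full size of this step stays unknown. A measured number is the exception among the compounds shown: the limit of > 25000 nM in this assay, at which 2 of the 3 values shown sit.

The compounds shown leave open how 4-methylphenyl would compare with 2-methylphenyl on this nitrogen. They also leave open whether 2-ethylphenyl or 2-methoxyphenyl would give a lower number than compound 1.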